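The source may report more compounds than this note shows. Statements on the series, on what has been measured and on what is new or still open speak of the compounds shown alone.

Measured compounds in this series:

compound 1 `O=C(N/N=C/c1cccc(O)c1)c1cccnc1Nc1cccc(C(F)(F)F)c1` — 67.5%
compound 2 `O=C(N/N=C/c1ccc(O)c(O)c1)c1cccnc1Nc1cccc(C(F)(F)F)c1` — 51.4%

Going by the values given here, in a functional assay on the whole organism (strain Wistar) for inhibition, with Rattus norvegicus as the target, read by paw edema, with a stated time of 30 min, at a dose of 10 mg/kg by the intraperitoneal route (on this read-out higher numbers stand for more inhibition at the one dose given (going by the name of the read-out) and lower numbers for less inhibition), compound 2 gives 51.4%, the lower of the two numbers; the only measured step is a number 16.1 percentage points lower from compound 1 to compound 2 (beyond the scatter), so compound 1 stands above it by that amount.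

Compound 3 `CN(C)c1ccc(/C=N/NC(=O)c2cccnc2Nc2cccc(C(F)(F)F)c2)cc1` is the next case. Relative to compound 2 the change is 4-(dimethylamino)phenyl in place of 3,4-dihydroxyphenyl on a carbon with a double bond to nitrogen. Among the compounds with values here, the one step that bears on it is a number 16.1 percentage points lower from compound 1 to compound 2 (beyond the scatter), where a hydroxy entered on an aromatic carbon and the inhibition fell by a modest but real amount. Within the data shown here, compound 3 carries no hydroxy at all in that part, so the loss seen in that step should not apply to it, but the 4-(dimethylamino)phenyl group has no counterpart among the measured compounds, and there is no basis for saying how it compares with the 3-hydroxyphenyl of compound 1. A step upward in this assay is therefore expected, of a size near that of the measured step, though with wide uncertainty.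

For compound 3 the expected value in this assay is 62%, with a range of 45% to 78%. This estimate corresponds to an expected step of a number 10.6 percentage points higher from compound 2 to compound 3 (beyond the scatter).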

Compound 3, a percentage reported as inhibition, in the whole organism at one dose (the size of the read-out at that dose, not a potency): 61.3%
Estimate against measurement, compound 3: 0.7 percentage points above, and the stated range covers the measured number.
By their numbers in this assay, from the lowest: compounds 2, 3 and 1 (each within the scatter of the next, the first and the last beyond it).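

In this assay, compound 3 places a group with no hydroxy, 4-(dimethylamino)phenyl, on the carbon with a double bond to nitrogen, and the comparisons give a number 6.2 percentage points lower from compound 1 to compound 3 (within the scatter) and a number 9.9 percentage points higher from compound 2 to compound 3 (within the scatter). A hydroxy on this phenyl is therefore not required for inhibition at the one dose given, and this position accepts a change of substituent type as well as the added hydroxy seen earlier. Compound 3 cannot be separated from either compound 1 or compound 2, although those two stand apart by a number 16.1 percentage points lower from compound 1 to compound 2 (beyond the scatter), so the three compounds do not fall into clear activity levels, and no measurement at hand explains these numbers.

The compounds shown leave open whether the dimethylamino group contributes anything itself, a question that an unsubstituted phenyl, a methoxy group or a primary amine on the same phenyl would help to settle. A carboxylic acid on this phenyl also remains untested here, and with a single dose and a single time, the read-out gives no potency ranking for any of these compounds.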